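Methyl in place of chloro on compound 2

The source may report more compounds than this note shows. Statements on the series, on what has been measured and on what is new or still open speak of the compounds shown alone.

Measured so far in a functional assay on KBVIN cells (Homo sapiens) for cytotoxicity, read by sulforhodamine B assay; on this read-out higher numbers stand for weaker inhibition of growth and lower numbers for stronger inhibition of growth:
- compound 1 `COc1ccc2c(c1)CCN2c1nc(Cl)nc2ccccc12` gives 197 nM
- compound 2 `COc1ccc2c(c1)CCCCN2c1nc(Cl)nc2ccccc12` gives 197 nM

The two values leave compound 2 level with compound 1, with no change at the digits shown and nothing beyond the scatter. Compound 3 `COc1ccc2c(c1)CCCCN2c1nc(C)nc2ccccc12` is the next to be read. It keeps the rest of compound 2 and differs in one place: methyl in place of chloro on an aromatic carbon. That carbon belongs to a six-membered aromatic ring with 2 nitrogen and sits between two ring nitrogen atoms.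

Among the compounds with values here, no measured pair shows this exchange, and both measured compounds carry chloro, so the data offer no size or direction for it. Within the data shown here, the only anchor is compound 2 at 197 nM. With nothing pointing either way, no step beyond the scatter is expected in this assay, though the uncertainty is wide. The estimated step is a 1.0-fold higher number from compound 2 to compound 3 (0.01 log units; within the scatter). For compound 3 the estimate is 200 nM, with an expected range from 60 nM to 650 nM.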

Compound 3, concentration for 50% growth inhibition: 20 nM
Compound 3: middle estimate off by 10-fold (1.00 log units), on the high side; the whole stated range lies above it.
By their numbers in this assay, from the lowest: compound 3; then compounds 1 and 2 (each within the scatter of the next).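

In this assay, the carbon between two ring nitrogen atoms proves sensitive to its substituent: methyl in place of chloro gives a 9.9-fold lower number from compound 2 to compound 3 (0.99 log units; beyond the scatter) and so marks this position as one where a single exchange moves the read-out beyond the scatter. Compounds 1 and 2 both carry chloro and could not show this; compound 3 now shows that chloro is not needed here for strong growth inhibition in these cells. The exchange swaps one heavy atom for one heavy atom, with the same count of rings, hydrogen-bond donors and acceptors and no net charge on either group, and no available measurement bears on the reason for the step.

On these data alone, with only chloro and methyl at this position, it remains open whether the trend continues with a larger alkyl group such as ethyl, or whether an amine, a methoxy group or plain hydrogen would read closer to compound 3 or to compound 2. As far as these compounds go, it is also open whether the same exchange on compound 1 would produce a step of similar size, or whether this one depends on the rest of compound 2.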